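Cyclohexyl in Place of Fluorophenyl on the Shared Core

A few compounds are considered here, and "the series" means these few. Any claim that something is new, unique, unknown or untested is made for them only; others in the source may bear on it.

Compound 1 `CN1CCC[C@@H]1Cn1nc(Cc2cccc(F)c2)c2ccccc2c1=O` gives 398 nM in an assay for binding affinity to Alpha-1B adrenergic receptor (Homo sapiens); on this read-out lower numbers stand for stronger inhibition and higher numbers for weaker inhibition. Compound 2 `O=c1c2ccccc2c(Cc2ccc(Cl)cc2)nn1C[C@H]1CCCN1CCCCCc1ccc(OCCCN2CCCCCC2)cc1` gives 50.1 nM in this assay. Compound 3 `CN(CCCCc1ccc(OCCCN2CCCCCC2)cc1)CCn1nc(Cc2ccc(Cl)cc2)c2ccccc2c1=O` gives > 1990 nM in this assay, which is a limit of the assay and not a number.

Among the two numbers shown, compound 1 stands highest; the nearest value, that of compound 2, lies lower by a gap beyond the usual scatter. Compound 3 is reported only as the limit of > 1990 nM in this assay, at which 1 of the 3 values shown sits. No pair among these measured compounds differs in a single place, so no measured step is available to guide the change considered here.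

Compound 4 `CN1CCC[C@@H]1Cn1nc(CC2CCCCC2)c2ccccc2c1=O` differs from compound 1 in one place: cyclohexyl in place of 3-fluorophenyl on a saturated chain carbon bound to an aromatic carbon. Within the data shown here, with no measured step of this kind, the expectation rests on the change itself: a saturated ring replaces an aromatic one of similar size, carrying no donors or acceptors either way. Such a change is expected to shift this assay by a modest amount, most likely toward a somewhat higher number, though a result within the scatter would not surprise. The step expected from compound 1 to compound 4 is a 1.8-fold higher number from compound 1 to compound 4 (0.25 log units; within the scatter). Compound 4 is therefore estimated at 700 nM, with a plausible range from 200 nM to 2500 nM.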

Compound 4, inhibition constant: > 1990 nM
Compound 4: only a limit was reported; the forecaster's own chance of this, stated with the estimate: 20%; middle value at least 2.8-fold (0.45 log units) away from the limit.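

Among these compounds, with the first measured step at this place, cyclohexyl in place of 3-fluorophenyl on a saturated chain carbon bound to an aromatic carbon gives an at least 5.0-fold higher number from compound 1 to compound 4 (0.69 log units; beyond the scatter) in this assay. Among the compounds shown here, the earlier compounds showed no single change of any kind, so this pair is the first to show that the group at this place can move the read-out by more than the scatter, and that a non-aromatic six-membered ring of carbon does not stand in for the aromatic one here without loss. The true size of the step stays unknown, since the result for compound 4 is a limit of the assay and not a number: the limit of > 1990 nM in this assay, at which 2 of the 4 values shown sit.

The change removes the fluorine and the aromatic ring together, and the compounds shown do not separate the two; plain phenyl at this place, with the fluorine gone and the aromatic ring kept, would tell them apart. Going by these compounds, whether a pyridyl ring, or a longer chain between the core and the ring, would be accepted at this place also remains open.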